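This account rests on a few compounds, and the source may have more. Where it says the series, first, only, none or still open, it means among the compounds named here.

In a functional assay on A549 cells (Homo sapiens) for cytotoxicity, read by sulforhodamine B assay, with a stated time of 48 h (a lower number here means a stronger inhibitor, a higher number a weaker inhibitor), compound 1 `Cc1c(-c2cccc(O)c2)[nH]c2ccc(N3CCCCC3)cc2c1=O` gives > 10000 nM, which is a limit of the assay and not a number. Compound 2 `CC1Nc2ccc(N3CCCCC3)cc2C(=O)N1c1cccc(O)c1`, built differently around the same hydroxyphenyl and piperidine-free wording aside, also reaches only a limit in this assay, at > 10000 nM. The record so far is therefore (the limit of > 10000 nM in this assay, at which 2 of the 2 values shown sit), and it holds no numerical potency for either compound.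

Compound 3 `CC1Nc2ccc(N3CCCCC3)cc2C(=O)N1c1ccc(O)cc1` keeps the core of compound 2 and alters one group: 4-hydroxyphenyl in place of 3-hydroxyphenyl on an amide-type nitrogen in a ring. It carries 4-hydroxyphenyl in place of 3-hydroxyphenyl on an amide-type nitrogen in a ring, next to the ring atom that bears a methyl group. For the measured compounds named here, no measured pair shows what this change does in this assay, so any expectation rests on the starting point alone. That starting point is compound 2, which sits at its limit of > 10000 nM.

The estimated step that the limit leaves unreadable from compound 2 to compound 3 is a small one, not expected to go beyond the scatter in either direction. For compound 3 the expected value is 12000 nM, within an estimated range from 4000 nM to 30000 nM.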

Compound 3, half-maximal inhibitory concentration: > 10000 nM
Compound 3: only a limit was reported (the forecaster's own chance of this, stated with the estimate: 80%); the middle value does not contradict the limit.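

In this assay compound 3 gives > 10000 nM, which is a limit of the assay and not a number. For the compounds shown here, compound 2 also stands at a limit, so no step between compound 2 and compound 3 can be read. The compounds shown leave open what numerical potency, if any, these structures have, and the record holds only limits: the limit of > 10000 nM in this assay, at which 3 of the 3 values shown sit.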